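Carboxymethyl for Benzyloxy: Cytotoxicity Expected to Remain Low

The compounds below may be only part of what the source reports. "The series", "measured", "known", "first", "only" and "open" are said of these compounds alone.

Measured compounds:
compound 1 `CC(C)N(Cc1cccc(OCCCCCC(=O)O)c1)C(=O)c1ccc(-c2ccc3c(c2)OCCO3)cc1`: > 21900 nM
compound 2 `CCOC(=O)CCCCCOc1cccc(CN(C(=O)c2ccc(-c3cccc(OCc4ccccc4)c3)cc2)C(C)C)c1`: > 26000 nM

Both measured compounds were tested in an ADME assay on HEK293 cells (Homo sapiens) for cytotoxicity, read by CellTiter-Glo and resazurin assay, with a stated time of 72 h; on this read-out lower numbers stand for an effect already at smaller amounts and higher numbers for an effect only at larger amounts of compound. For compound 1 the result is a limit of the assay and not a number, > 21900 nM. For compound 2 the result is likewise a limit, > 26000 nM. For the measured compounds named here, compound 2 therefore stands at a limit rather than at a measured point, as does the one further value shown, which is described by the limit of > 21900 nM in this assay, at which 1 of the 2 values shown sits, and (the limit of > 26000 nM in this assay, at which 1 of the 2 values shown sits). Going by the values given here, no measured pair differs in a single place, so no step size has been observed.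

Compound 3 `CCOC(=O)CCCCCOc1cccc(CN(C(=O)c2ccc(-c3cccc(CC(=O)O)c3)cc2)C(C)C)c1` differs from compound 2 by carboxymethyl in place of benzyloxy on an aromatic carbon. With both measured compounds sitting at limits, the expectation is that compound 3 also reaches no measurable effect within the tested range, and the step of a number no higher from compound 2 to compound 3 (the limit leaves the size open) is expected to lie within the usual scatter rather than beyond it. For compound 3 in this assay the estimated value is 26000 nM, expected to fall between 13000 nM and 52000 nM.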

Compound 3, half-maximal effective concentration: > 26000 nM
Compound 3: only a limit was reported (the forecaster's own chance of this, stated with the estimate: 85%); the middle value sits exactly at the limit.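

In this assay, compound 2 and compound 3 both end at a limit of the assay rather than at a number, so the step between them cannot be read. The compounds shown leave open at what concentration any of them would harm these cells, and whether carboxymethyl in place of benzyloxy changes that concentration.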